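Iodo for Bromo on a Shared Aminothiophene Ketone Core

The source may report more compounds than this note shows. Statements on the series, on what has been measured and on what is new or still open speak of the compounds shown alone.

Compound 1: `Nc1scc(-c2ccc(Br)cc2)c1C(=O)c1ccccc1` — 46%
Compound 2: `Nc1scc(-c2ccc(I)cc2)c1C(=O)c1ccccc1` — 51%
Compound 3: `Nc1scc(-c2ccc(Br)cc2)c1C(=O)c1ccc(Cl)cc1` — 45%

Of the compounds shown here, three have been tested in a functional assay on CHO cells for agonist activity at adenosine receptor A1 (Homo sapiens), read by fluorescence and ERK phosphorylation, with stated times of 30 min and 1.5 h, tested at 3 uM; a lower number here means a weaker effect, a higher number a stronger effect of the compound at the concentration tested. In this assay compound 1 gives 46%, compound 2 gives 51% and compound 3 gives 45%. All three numbers lie close to each other. The change from compound 1 to compound 2 is iodo in place of bromo on an aromatic carbon, and it gives a number 5 percentage points higher from compound 1 to compound 2 (within the scatter). The change from compound 1 to compound 3 is chloro in place of hydrogen on an aromatic carbon, and it gives a number 1 percentage points lower from compound 1 to compound 3 (within the scatter). Compound 4, `Nc1scc(-c2ccc(I)cc2)c1C(=O)c1ccc(Cl)cc1`, has not yet been measured in this assay. Among the measured compounds shown here, it differs from compound 3 by iodo in place of bromo on an aromatic carbon, which is the same change, at the same place, as the one from compound 1 to compound 2; the two place descriptions agree word for word. That change appears twice among the four compounds, once measured and once not. Since the measured instance of this change stayed within the scatter, as shown by a number 5 percentage points higher from compound 1 to compound 2 (within the scatter), compound 4 is expected to sit near compound 3, with an expected step of a number 5 percentage points higher from compound 3 to compound 4 (within the scatter). The estimate for compound 4 in this assay is 50%, with a range from 36% to 62%.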

Compound 4, a percentage reported as activity, at one concentration (the size of the read-out at that concentration, not a potency): 54%
The estimate for compound 4 lay 4 percentage points below the measured number; the measured number falls inside the stated range.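

In this assay, iodo in place of bromo on the 4-bromophenyl group gave a number 9 percentage points higher from compound 3 to compound 4 (within the scatter), and this step agrees with the earlier one, so the change carried from one core to the other without a detectable difference: the same change on two cores in this assay, a number 5 percentage points higher (within the scatter) from compound 1 to compound 2 and a number 9 percentage points higher (within the scatter) from compound 3 to compound 4, 4 percentage points apart, within the scatter of two such steps. The second change, chloro in place of hydrogen on an aromatic carbon, gave a number 3 percentage points higher from compound 2 to compound 4 (within the scatter), and it also carried across the two cores without a detectable difference: the same change on two cores in this assay, a number 1 percentage points lower (within the scatter) from compound 1 to compound 3 and a number 3 percentage points higher (within the scatter) from compound 2 to compound 4, 4 percentage points apart, within the scatter of two such steps. Among the compounds shown here, this does not show that either change has any real effect on the read-out, since all of these steps lie within the scatter; the agreement is therefore one between small steps, seen on only two cores and at a single concentration, and it says nothing about potency or about whether a larger step would carry over in the same way.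

The compounds shown differ only in their halogens, which leaves open what a methoxy group, an amine or a carboxylic acid would do in place of the iodo or bromo group. On these data alone, it also remains open whether any change that produces a step beyond the scatter would carry from one core to another.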